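Swapping an Aromatic Amide Cap for a Flexible Chain

The source may hold more compounds than are shown below. What is called first, only, known or untested is meant among the compounds shown, and "the series" means these compounds.

Compound 1 `Cc1cccc(Oc2ccnc(N3CCN(C(=O)c4c(C)noc4C)CC3)n2)c1` was tested in an assay on isolated protein for inhibition of Ephrin type-B receptor 4 (Homo sapiens), read by HTRF, tested at 10 uM (a higher number here means more inhibition at the concentration tested (going by the name of the read-out), a lower number less inhibition), where compound 1 gives 0%. Two structurally unrelated compounds show the same picture: compound 2 `Clc1ccc2sc(CN3CCN(c4ncnc5c4CN(Cc4ccccc4)CC5)CC3)cc2c1` gives 0% and compound 3 `COC[C@@H]1CCCN1C(=O)[C@@H]1CCCN1c1nccc(Nc2ccccc2)n1` gives 0%, so compound 1 stands level with both at the digits shown, within the scatter. Compound 4 `CC(=O)CCCCC(=O)N1CCN(c2nccc(Oc3cccc(C)c3)n2)CC1` keeps the core of compound 1 and alters only the group on the carbonyl carbon: 4-acetylbutyl in place of 3,5-dimethyl-1,2-oxazol-4-yl on a carbonyl carbon. Within the data shown here, no step between measured compounds exists to guide the size of this change. Among the measured compounds shown here, because compound 1 gives 0% and no compound in the set moves away from that value, the step is expected to stay within the scatter: a number 2 percentage points higher from compound 1 to compound 4 (within the scatter). Compound 4 is therefore expected to give 2%, between -8% and 12%.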

Compound 4, a percentage reported as inhibition, at one concentration (the size of the read-out at that concentration, not a potency): 0%
Estimate against measurement, compound 4: 2 percentage points above; measured number inside the range.
By their numbers in this assay, from the lowest: compounds 1, 2, 3 and 4 (each within the scatter of the next).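

In this assay, among these compounds, 4-acetylbutyl in place of 3,5-dimethyl-1,2-oxazol-4-yl on a carbonyl carbon gives no change at the digits printed from compound 1 to compound 4 (within the scatter) and so offers the first direct comparison at this position. An open chain and an aromatic ring here read the same, but both compounds sit at the bottom of the read-out, so the step cannot show whether this position matters. No measurement shown offers an explanation for this result. On these data alone, whether a primary amine or a carboxylic acid at the end of the chain would produce any measurable inhibition remains open. So does whether any change on this carbonyl can lift the shared core off that reading.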